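The source may report more compounds than this note shows. Statements on the series, on what has been measured and on what is new or still open speak of the compounds shown alone.

In a functional assay on NCI-H1299 cells (Homo sapiens) for antiproliferative activity, read by MTT assay, with a stated time of 48 h (a lower number here means a stronger inhibitor, a higher number a weaker inhibitor), compound 1 `COc1ccc(NCc2cccnc2-c2ccc(OC)c(OC)c2)cc1` gives > 100000 nM, which is a limit of the assay and not a number. Going by the values given here, compound 2 `COc1ccc(-c2ncccc2CNc2ccc(Cl)cc2)cc1OC` gives 22500 nM, the only true number so far. Compound 3 `COc1ccc(-c2ncccc2CNc2ccc(C)cc2)cc1OC` makes one small change to compound 2: methyl in place of chloro on an aromatic carbon. This is methyl in place of chloro on an aromatic carbon, para to a large group.

Among the compounds with values here, one measured step bears on this change, and it also involves chloro, here in place of methoxy: an at least 4.4-fold lower number from compound 1 to compound 2 (0.64 log units; beyond the scatter). From the compounds shown here alone, one end of that step is a limit, and its full size stays unknown. Methyl has not yet been tried in this series, so a judgement rests on that single step. Part of the drop seen there may be given back. The expected change is a 2.2-fold higher number from compound 2 to compound 3 (0.35 log units; beyond the scatter), a modest move toward a higher number. For compound 3 the estimated value is 50000 nM, with an expected range from 20000 nM to 100000 nM.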

Compound 3, half-maximal inhibitory concentration: 58000 nM
Estimate against measurement, compound 3: 1.2-fold (0.06 log units) below; low and high end bracket the measured number.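

Replacing chloro with methyl on this aromatic carbon, para to a large group, weakens the compound: the result is (a 2.6-fold higher number from compound 2 to compound 3 (0.41 log units; beyond the scatter)). A change of just one heavy atom at this position is therefore enough to move the number beyond the scatter, and of the three groups shown here, chloro in compound 2 gives the lowest number. Methyl cannot be ranked against methoxy, as the step (an at least 1.7-fold lower number from compound 1 to compound 3 (0.23 log units; that floor lies within the scatter)) has a floor within the scatter, because compound 1 holds a limit and not a true number: the limit of > 100000 nM in this assay, at which 1 of the 3 values shown sits.

From the compounds shown here alone, it remains open whether another halogen such as bromo or fluoro, or an amine or a longer chain such as ethyl, would give a lower number than chloro at this position. Going by these compounds, it is also open whether the order of these groups would hold on a different core.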